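The source may hold more compounds than are shown below. What is called first, only, known or untested is meant among the compounds shown, and "the series" means these compounds.

Measured so far in an ADME assay on the whole organism (Rattus norvegicus, strain Sprague-Dawley) for pharmacokinetics, read by LC-MS, at a dose of 5 mg/kg by the oral route; on this read-out higher numbers stand for higher oral bioavailability and lower numbers for lower oral bioavailability:
compound 1 `Cc1cccc(F)c1CN1CCc2cc(-c3c(C)nc(C)c([C@H](OC(C)(C)C)C(=O)O)c3N3CCC(C)(C)CC3)ccc2C1` gives 70%
compound 2 `Cc1nc(C)c([C@H](OC(C)(C)C)C(=O)O)c(N2CCC(C)(C)CC2)c1-c1ccc2c(c1)CCN(Cc1cccc(F)c1C)C2` gives 64%

Compound 2 and compound 1 cannot be told apart in this assay: a number 6 percentage points lower from compound 1 to compound 2 (within the scatter). That single step exchanges one fluoro-methyl-substituted benzyl for another and says nothing about what happens when the benzyl is given up altogether.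

Compound 3 `Cc1nc(C)c([C@H](OC(C)(C)C)C(=O)O)c(N2CCC(C)(C)CC2)c1-c1ccc2c(c1)CCN(c1ncnc3c1cnn3C)C2` makes that kind of change: a group of 10 heavy atoms (6 carbon, 4 nitrogen; one five-membered aromatic ring with 2 hetero atoms, one six-membered aromatic ring with 2 hetero atoms) in place of a group of 9 heavy atoms (8 carbon, 1 fluorine; one six-membered aromatic ring of carbon only), on an amine nitrogen in a ring. Among the compounds with values here, no measured step bears on it; the only step in hand keeps an aromatic ring of carbon only on the amine nitrogen in the ring, whereas here the fluorine leaves and two aromatic rings with hetero atoms enter in its place. The direction in this assay is therefore open, and so is the size; a move either way beyond the scatter cannot be excluded, nor can no move at all.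

For compound 3 the value in this assay is expected to be 50%, with a range of 20% to 80%. Within the data shown here, that estimate means an expected step of a number 14 percentage points lower from compound 2 to compound 3 (beyond the scatter), set wide because there is no precedent for it in a number 6 percentage points lower from compound 1 to compound 2 (within the scatter).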

Compound 3, oral bioavailability: 95%
Estimate against measurement, compound 3: 45 percentage points below; the whole stated range lies below it.
By their numbers in this assay, from the lowest: compounds 2 and 1 (each within the scatter of the next); then compound 3.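

In this assay the amine nitrogen in a ring proves far more sensitive to a change of group type than the earlier exchange of one fluoro-methyl-substituted benzyl for another could show: giving up the 3-fluoro-2-methylbenzyl for the group with two aromatic rings bearing hetero atoms gives a number 31 percentage points higher from compound 2 to compound 3 (beyond the scatter) and marks this as a position where the read-out can be moved. The same change measured against the other benzyl gives a number 25 percentage points higher from compound 1 to compound 3 (beyond the scatter) and so does not depend on which of the two benzyl compounds serves as the reference, and neither benzyl is needed for high oral bioavailability in this series. Nothing at hand accounts for the gain, and these compounds cannot say which part of the entering group carries it.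

From the compounds shown here alone, whether a single aromatic ring such as pyrimidine or pyridine on that nitrogen would match the fused group remains open, as does the contribution of the methyl on the entering group. Also open, going by these compounds, is whether the gain would survive with a carbonyl-linked amide or a plain alkyl chain at the same place, or with a different group elsewhere on the shared core.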